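The source may report more compounds than this note shows. Statements on the series, on what has been measured and on what is new or still open speak of the compounds shown alone.

Compounds measured so far:
- Compound 1 `Cc1ccccc1Nc1nc(SCc2cn(Cc3ccc(Cl)cc3)nn2)nc(-c2ccccc2)c1C#N`: in a functional assay on ECa-109 cells (Homo sapiens) for inhibition, read by MTT assay, with a stated time of 72 h (on this read-out lower numbers stand for stronger inhibition and higher numbers for weaker inhibition), compound 1 gives > 64000 nM, which is a limit of the assay and not a number.
- Compound 2 `Cc1ccc(Nc2nc(SCc3cn(Cc4ccc(Cl)cc4)nn3)nc(-c3ccccc3)c2C#N)cc1`: in this assay compound 2 gives > 64000 nM, again a limit.
- Compound 3 `N#Cc1c(Nc2ccccc2F)nc(SCc2cn(Cc3ccc(Cl)cc3)nn2)nc1-c1ccccc1`: in this assay compound 3 gives > 64000 nM, again a limit.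

Compound 2 therefore stands at the limit, and the two further values sit there as well (the limit of > 64000 nM in this assay, at which 3 of the 3 values shown sit). The steps among these three, a step that the two limits leave unreadable from compound 1 to compound 2, a step that the two limits leave unreadable from compound 1 to compound 3 and a step that the two limits leave unreadable from compound 2 to compound 3, are all left unreadable by the limits; they concern only the aryl group on the nitrogen.

Compound 4 `Cc1ccc(Cn2cc(CSc3nc(Nc4ccc(C)cc4)c(C#N)c(-c4ccccc4)n3)nn2)cc1` is the next member. It differs from compound 2 in one place: methyl in place of chloro on an aromatic carbon. Going by the values given here, no measured step touches this benzyl position, so nothing read so far bears directly on it; the only guide is that every change tried has left the value at the limit. Compound 4 is expected to stay there too, estimated at 90000 nM with a range of 30000 nM to 300000 nM. The step that the limit leaves unreadable from compound 2 to compound 4 is accordingly expected to be none beyond the scatter.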

Compound 4, half-maximal inhibitory concentration: 55700 nM
Compound 4: middle estimate off by 1.6-fold (0.21 log units), on the high side; low and high end bracket the measured number.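

Going by these compounds alone, the change from 4-chlorobenzyl to 4-methylbenzyl gives the first readable number in this assay: compound 4 gives 55700 nM. Compound 2 gives > 64000 nM, which is a limit of the assay and not a number, and it sits where most of the series sits: the limit of > 64000 nM in this assay, at which 3 of the 4 values shown sit.

Methyl in place of chloro on this aromatic carbon thus gives an at least 1.1-fold lower number from compound 2 to compound 4 (0.06 log units; that floor lies within the scatter), so this position can yield a measurable value, but the floor alone shows no change beyond the scatter.

On these data alone, the true size of the step stays open, as only its floor can be read. Also open, as far as these compounds go, is what a methoxy group, an amine or a carboxylic acid on this aromatic carbon would give, and whether any such group would bring a value clearly clear of the limit.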